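Lengthening the linker: from compound 2 to compound 4

A few compounds are considered here, and "the series" means these few. Any claim that something is new, unique, unknown or untested is made for them only; others in the source may bear on it.

Of the compounds shown here, three sharing one core have been tested in an ADME assay on L6 cells (Rattus norvegicus) for cytotoxicity, read by resazurin assay, with a stated time of 70 h; on this read-out higher numbers stand for weaker inhibition and lower numbers for stronger inhibition. Compound 1 `N=C(N)c1ccc2cc(-c3ccc(OCCCOc4ccccc4)cc3)oc2c1` gives 8600 nM, compound 2 `N=C(N)c1ccc2cc(-c3ccc(OCCCCOc4ccccc4)cc3)oc2c1` gives 14100 nM, and compound 3 `c1ccc(OCCCCOc2ccc(-c3cc4ccc(C5=NCCN5)cc4o3)cc2)cc1` gives 16900 nM. Compound 2 thus sits second highest of the three, with all three numbers within the scatter of one another. The step of a 1.6-fold higher number from compound 1 to compound 2 (0.21 log units; within the scatter) and the step of a 1.2-fold higher number from compound 2 to compound 3 (0.08 log units; within the scatter) were both small. Within the data shown here, compound 4 `N=C(N)c1ccc2cc(-c3ccc(OCCCCCOc4ccccc4)cc3)oc2c1` differs from compound 2 by phenoxymethyl in place of phenoxy on a saturated chain carbon, four bonds along the chain from an oxygen on an aromatic ring, a change of the same kind as the one from compound 1 to compound 2. Because that earlier step was a 1.6-fold higher number from compound 1 to compound 2 (0.21 log units; within the scatter), no movement beyond the scatter is expected here, so compound 4 is estimated at 16000 nM, with a range from 8000 nM to 32000 nM, a step of a 1.1-fold higher number from compound 2 to compound 4 (0.05 log units; within the scatter) in this assay.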

Compound 4, half-maximal inhibitory concentration: 9000 nM
The estimate for compound 4 lay 1.8-fold (0.25 log units) above the measured number; low and high end bracket the measured number.
By their numbers in this assay, from the lowest: compounds 1, 4, 2 and 3 (each within the scatter of the next).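

In this assay, phenoxymethyl in place of phenoxy on the chain gives a 1.6-fold lower number from compound 2 to compound 4 (0.19 log units; within the scatter), and 2-phenoxyethyl in place of phenoxy gives a 1.0-fold higher number from compound 1 to compound 4 (0.02 log units; within the scatter). The earlier compounds shown here showed a single lengthening of this chain, whereas these steps show that a further lengthening also stays within the scatter, so no trend with chain length can be read from compounds 1, 2 and 4. Still open, from the compounds shown here alone, is whether a longer chain, or an amine in place of the phenoxy group, would move the number beyond the scatter. No available evidence bears on this result.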